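The source may hold more compounds than are shown below. What is called first, only, known or untested is meant among the compounds shown, and "the series" means these compounds.

The series shares one core and varies the groups hung on it. In a functional assay on BMDM cells (Mus musculus, strain C57BL/6) for inhibition, with a stated time of 2 days (a lower number here means a stronger inhibitor, a higher number a weaker inhibitor), compound 1 `CCOC(=O)c1sc(NC(=O)Cn2cc(-c3ccc(OC)cc3)nn2)nc1C` gives 2330 nM, compound 2 `COc1ccc(-c2cn(CC(=O)Nc3nc(C)cs3)nn2)cc1` gives 3890 nM, and compound 3 `Cc1csc(NC(=O)Cn2cc(-c3ccc(F)cc3)nn2)n1` gives 250 nM. Compound 1 thus stands second highest of the three numbers: its nearest neighbour is compound 2, separated by a 1.7-fold higher number from compound 1 to compound 2 (0.22 log units; within the scatter), while compound 3 lies furthest away with a lower number.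

Compound 4 `CCOC(=O)c1sc(NC(=O)Cn2cc(-c3ccncc3)nn2)nc1C` has not yet been measured in this assay. It differs from compound 1 in one place: pyridin-4-yl in place of 4-methoxyphenyl on an aromatic carbon.

Of the measured steps, the one that bears most on this change is the replacement of the substituent on the same pendant aromatic ring, a 16-fold lower number from compound 2 to compound 3 (1.19 log units; beyond the scatter), which shows that this ring is sensitive to what it carries. The step of a 1.7-fold higher number from compound 1 to compound 2 (0.22 log units; within the scatter) concerns a different place and says little here. For the measured compounds named here, no measured pair swaps the whole ring for pyridin-4-yl, so the direction is open; the one relevant step points toward a lower number when the methoxy is removed, but a ring nitrogen is not a fluoro. Compound 4 is therefore expected to show a 1.7-fold lower number from compound 1 to compound 4 (0.22 log units; within the scatter), a modest shift with wide uncertainty, giving an estimate of 1400 nM within a range from 350 nM to 5600 nM.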

Compound 4, half-maximal inhibitory concentration: 120 nM
Estimate against measurement, compound 4: 12-fold (1.07 log units) above, and the stated range ends above it.
By their numbers in this assay, from the lowest: compound 4; then compound 3; then compounds 1 and 2 (each within the scatter of the next).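

In this assay, placing pyridin-4-yl where 4-methoxyphenyl stood gives a 19-fold lower number from compound 1 to compound 4 (1.29 log units; beyond the scatter), so exchanging the whole ring on this aromatic carbon of the five-membered aromatic ring with 3 nitrogen moves the number by a step beyond the scatter. The earlier compounds shown here showed only an exchange of the group carried on the pendant ring, a 16-fold lower number from compound 2 to compound 3 (1.19 log units; beyond the scatter), in compounds without the ethoxycarbonyl; the new step shows that this position also responds in a compound that carries ethoxycarbonyl, and when a ring nitrogen enters. The counted hydrogen-bond donors, hydrogen-bond acceptors and net charge are the same for the group that leaves and the group that enters, and nothing measured here accounts for the size of the step.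

The compounds shown leave open whether the lower number goes with the ring nitrogen itself or with the loss of the methoxy, a question that an unsubstituted phenyl on the same core would separate. They also leave open whether the place of that nitrogen matters, as pyridin-3-yl or pyridin-2-yl would show, and whether pyridin-4-yl acts alike on the core without ethoxycarbonyl.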